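The source may report more compounds than this note shows. Statements on the series, on what has been measured and on what is new or still open speak of the compounds shown alone.

Working notes on the series. The read-out throughout is a functional assay on Vero cells (Chlorocebus sabaeus) for inhibition; a higher number here means a weaker inhibitor, a lower number a stronger inhibitor. Compound 1 `Nc1ccn([C@@H]2O[C@@H](CO)C=C2F)c(=O)n1` is the parent of the first pair. In this assay compound 1 gives > 100000 nM, which is a limit of the assay and not a number. Compound 2 `Nc1nc(=O)n([C@@H]2O[C@@H](CO)C=C2F)cc1F` differs from compound 1 by fluoro in place of hydrogen on an aromatic carbon. In this assay compound 2 gives > 100000 nM, again a limit rather than a number. The step that the two limits leave unreadable from compound 1 to compound 2 therefore cannot be read. Compound 3 `Nc1ncnc2c1ncn2[C@@H]1O[C@@H](CO)C=C1F` is built on a different core; the difference between the two cores is not broken down here. In this assay compound 3 gives > 100000 nM, also a limit. What the measured set shows is the limit of > 100000 nM in this assay, at which 3 of the 3 values shown sit.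

Compound 4 `Nc1nc(F)nc2c1ncn2[C@@H]1O[C@@H](CO)C=C1F` is yet to be measured. It differs from compound 3 by fluoro in place of hydrogen on an aromatic carbon. This is the same kind of change as that from compound 1 to compound 2, but not the same change: in compound 2 the fluoro sits ortho to an amino group, two atoms from the ring nitrogen, meta to a group of 8 heavy atoms and para to a group of 1 heavy atom, whereas in compound 4 it sits between two ring nitrogen atoms of a ring that is part of a fused or bridged system of two rings, meta to a fused ring, meta to an amino group and para to a fused ring.

The step from compound 3 to compound 4 in this assay is expected to be a step that the limit leaves unreadable from compound 3 to compound 4, set beside the earlier unreadable step. That expectation rests on compound 3 giving > 100000 nM, a limit, and on (the limit of > 100000 nM in this assay, at which 3 of the 3 values shown sit). Compound 4 is accordingly estimated at 150000 nM in this assay, most probably reported once more only as a limit.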

Compound 4, half-maximal inhibitory concentration: > 100000 nM
Compound 4 gave a limit, no number; the forecaster's own chance of this, stated with the estimate: 85%; the middle value is on the limit's open side.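

In this assay compound 4 gives > 100000 nM, a limit of the assay and not a number, so no new step can be read from compound 3 to compound 4. What stays open is whether fluoro in place of hydrogen on an aromatic carbon alters inhibition in either pair, as the compounds shown offer no number to compare: the limit of > 100000 nM in this assay, at which 4 of the 4 values shown sit.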